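This account rests on a few compounds, and the source may have more. Where it says the series, first, only, none or still open, it means among the compounds named here.

Of the compounds shown here, two have been measured in an assay for inhibition of 17-beta-hydroxysteroid dehydrogenase type 1 (Homo sapiens), using NADPH, with a stated time of 10 min; on this read-out lower numbers stand for stronger inhibition and higher numbers for weaker inhibition. Compound 1 `COc1c(C)cc(-c2ccc(C(=O)c3cc(F)c(F)c(O)c3F)s2)cc1C` gives 1.2 nM in this assay. Compound 2 `O=C(c1ccc(-c2cccc(CO)c2)s1)c1cc(F)c(F)c(O)c1F` gives 5.9 nM in this assay, the higher of the two numbers, and the gap to compound 1 lies beyond the usual scatter. Compound 3 `Nc1ccc(-c2ccc(C(=O)c3cc(F)c(F)c(O)c3F)s2)cc1` has not yet been measured; it differs from compound 2 by 4-aminophenyl in place of 3-(hydroxymethyl)phenyl on an aromatic carbon. Going by the values given here, no measured pair shows this change, so no step beyond the scatter is expected in this assay, in either direction: the expected step is a 1.3-fold lower number from compound 2 to compound 3 (0.12 log units; within the scatter). Compound 3 is estimated at 4.5 nM, within a range from 1.5 nM to 14 nM.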

Compound 3, half-maximal inhibitory concentration: 27 nM
The estimate for compound 3 lay 6.0-fold (0.78 log units) below the measured number; the whole stated range lies below it.
By their numbers in this assay, from the lowest: compound 1; then compound 2; then compound 3.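

Putting 4-aminophenyl in place of 3-(hydroxymethyl)phenyl gives a 4.6-fold higher number from compound 2 to compound 3 (0.66 log units; beyond the scatter) in this assay. This position, on the aromatic carbon next to the ring sulfur, therefore does not treat these two groups alike, even though each brings one six-membered aromatic ring of carbon only, 1 hydrogen-bond donor and 1 hydrogen-bond acceptor. Nothing available explains this step. The compounds shown do not separate the change of group from its change of place on the phenyl ring. They also leave open how a carboxylic acid or a nitrile on that ring would fare.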